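The source may report more compounds than this note shows. Statements on the series, on what has been measured and on what is new or still open speak of the compounds shown alone.

In a functional assay on HL-60 cells (Homo sapiens) for inhibition, read by CCK-8 assay, with a stated time of 48 h, tested at 20 uM (a lower number here means less inhibition of growth, a higher number more inhibition of growth at the concentration tested), compound 1 (`N#C/C(=C\c1ccccc1OS(=O)(=O)c1ccc([N+](=O)[O-])cc1)C(=O)Nc1nnc(-c2cccs2)s1`) gives 23%. Compound 2 (`Cc1ccc(S(=O)(=O)Oc2ccccc2/C=C(\C#N)C(=O)Nc2nnc(Cc3ccc(F)cc3)s2)cc1`) is reported as "not active" (no number reported), so it stands without a single number, and any comparison with it can only be loose. Compound 3 (`N#C/C(=C\c1ccccc1OS(=O)(=O)c1ccc([N+](=O)[O-])cc1)C(=O)Nc1nnc(Cc2ccc(F)cc2)s1`) has not yet been measured in this assay. Its structure departs from the earlier one in a single place: nitro in place of methyl on an aromatic carbon. In words, nitro takes the place of methyl on an aromatic carbon, turning 4-methylphenyl into 4-nitrophenyl. Among the measured compounds shown here, no measured pair shows what this swap does, so the expected step is small and upward, from no reported activity to a low figure. For the measured compounds named here, the only guide is compound 1, which also carries (4-nitrophenyl)sulfonyl, differs elsewhere, and gives 23%. For compound 3 the expected growth inhibition is estimated at 18%, within a range of 3% to 40%.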

Compound 3, percent growth inhibition at one concentration: 18%
Estimate against measurement, compound 3: no gap at the digits printed, and the stated range covers the measured number.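

In this assay, replacing thiophen-2-yl with 4-fluorobenzyl while keeping (4-nitrophenyl)sulfonyl gives a number 5 percentage points lower from compound 1 to compound 3 (within the scatter), so these two groups cannot be told apart in this test. Compound 3 gives 18%, whereas compound 2, which carries 4-methylphenyl in place of 4-nitrophenyl, is reported only as not active, so nitro goes with a measurable reading here, but the size of that change cannot be read without a number for compound 2. No accompanying measurement explains either result. From the compounds shown here alone, it remains open whether an amine or a carboxylic acid on the same aromatic carbon would match the nitro compound or differ from it by more than the scatter. A longer alkyl chain in place of 4-fluorobenzyl is equally untested by the compounds shown.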